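This account rests on a few compounds, and the source may have more. Where it says the series, first, only, none or still open, it means among the compounds named here.

Compound 1 `Cc1cc(=O)oc2cc(OCc3nc(N)nc(Nc4ccc(F)cc4)n3)ccc12` gives 18300 nM in an assay on COS-7 cells for agonist activity at Free fatty acid receptor 1 (Homo sapiens), read by scintillation counting and inositol phosphate accumulation, with a stated time of 90 min; on this read-out lower numbers stand for an effect already at smaller amounts and higher numbers for an effect only at larger amounts of compound. Compound 2 `Cc1cc(=O)oc2cc(OCc3nc(N)nc(Nc4ccc5c(c4)COC5)n3)ccc12` gives 1330 nM in this assay.

Going by the values given here, of these two numbers compound 2 has the lowest; the only step measured, a 14-fold lower number from compound 1 to compound 2 (1.14 log units; beyond the scatter), separates it from compound 1. Compound 3 `Cc1cc(Nc2nc(N)nc(COc3ccc4c(C)cc(=O)oc4c3)n2)ccc1Cl` changes the same position: a group of 8 heavy atoms (7 carbon, 1 chlorine; one six-membered aromatic ring of carbon only) in place of a group of 9 heavy atoms (8 carbon, 1 oxygen; one five-membered non-aromatic ring with 1 hetero atom, one six-membered aromatic ring of carbon only), on a nitrogen on an aromatic ring. Among the compounds with values here, the one step that bears on this change is a 14-fold lower number from compound 1 to compound 2 (1.14 log units; beyond the scatter), a large one at this nitrogen. Since compound 3 returns to a single aromatic ring carrying a halogen, as in compound 1, the number is expected to rise, a 4.5-fold higher number from compound 2 to compound 3 (0.65 log units; beyond the scatter), though perhaps not all the way back. Compound 3 is estimated at 6000 nM, in a range from 1800 nM to 20000 nM.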

Compound 3, half-maximal effective concentration: 240 nM
Beside the measured number, compound 3's estimate is 25-fold (1.40 log units) above it, and the stated range ends above it.
By their numbers in this assay, from the lowest: compound 3; then compound 2; then compound 1.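

In this assay a single aromatic ring at this nitrogen proves no drawback: 4-chloro-3-methylphenyl gives a 5.5-fold lower number from compound 2 to compound 3 (0.74 log units; beyond the scatter), so the five-membered non-aromatic ring of compound 2 is not required for a low number. Against 4-fluorophenyl, the same group gives a 76-fold lower number from compound 1 to compound 3 (1.88 log units; beyond the scatter), so single-ring groups here are far from equal. Nothing shown here explains these differences. Chlorine and methyl enter together, so which of them carries the step stays open. Also open, on these data alone, is how an amine or a carboxylic acid on this ring would read.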